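Amino in place of hydrogen on a fused two-ring core

This account rests on a few compounds, and the source may have more. Where it says the series, first, only, none or still open, it means among the compounds named here.

Of the compounds shown here, three have been measured in a functional assay on MDA-MB-231 cells (Homo sapiens) for antiproliferative activity, read by MTT assay, with a stated time of 72 h; a lower number here means a stronger inhibitor, a higher number a weaker inhibitor. Compound 1 `COc1cccc(CNc2ncnc3ccc(-c4cnn(C)c4)cc23)c1` gives 28500 nM in this assay. Compound 2 `CC(Nc1nc(N)nc2ccc(-c3cnn(C4CCNCC4)c3)cc12)c1c(Cl)ccc(F)c1Cl` gives 4480 nM in this assay. Compound 3 `CC(Oc1ncnc2ccc(-c3cnn(C4CCNCC4)c3)cc12)c1c(Cl)ccc(F)c1Cl` gives 6770 nM in this assay, the second highest of the three numbers; its value and that of compound 2 sit within the usual scatter of each other, while compound 1 stands clearly higher, beyond the scatter. Compound 4 `CC(Oc1nc(N)nc2ccc(-c3cnn(C4CCNCC4)c3)cc12)c1c(Cl)ccc(F)c1Cl` has not yet been measured. It differs from compound 3 in one place: amino in place of hydrogen on an aromatic carbon. Going by the values given here, no pair of measured compounds differs in just this one place, so the size of this step cannot be read from a measured pair. Compound 2, which carries the same amino group, gives 4480 nM in this assay, and on that basis a small downward step is expected, though one that may well stay within the scatter. Compound 4 is therefore estimated at 4000 nM in this assay, between 1500 nM and 12000 nM, a step from a 1.7-fold lower number from compound 3 to compound 4 (0.23 log units; within the scatter).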

Compound 4, half-maximal inhibitory concentration: 7000 nM
Estimate against measurement, compound 4: 1.8-fold (0.24 log units) below, within the range that was stated.
By their numbers in this assay, from the lowest: compounds 2, 3 and 4 (each within the scatter of the next); then compound 1.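

In this assay, amino in place of hydrogen on an aromatic carbon, between two ring nitrogen atoms, gives a 1.0-fold higher number from compound 3 to compound 4 (0.01 log units; within the scatter), so the two compounds cannot be told apart. Going by these compounds alone, this is the first measured pair for this change, and it shows that, with this side group and this pyrazole-bearing substituent in place, adding the amino group at this position produces no step beyond the scatter. Nothing available here offers an explanation for this result.

The compounds shown leave open whether a methyl, a methylamino or a hydroxyl group at this position would give a step beyond the scatter. They also leave open whether amino in place of hydrogen would behave the same way on the core of compound 1, with its different substituents.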